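Chloro in place of methyl: compound 1 to compound 4

The source may hold more compounds than are shown below. What is called first, only, known or untested is meant among the compounds shown, and "the series" means these compounds.

Within the data shown here, in an ADME assay on Vero cells (Chlorocebus sabaeus) for cytotoxicity, read by MTT assay, with a stated time of 72 h (on this read-out higher numbers stand for an effect only at larger amounts of compound and lower numbers for an effect already at smaller amounts), compound 1 `Cc1ccccc1C(=O)Nc1nc(-c2ccccn2)cs1` gives 6300 nM, the higher of the two numbers so far. Compound 2 `COc1cccc(C(=O)Nc2nc(-c3ccccn3)cs2)c1` gives 2800 nM, a gap beyond the usual scatter. Compound 3 `O=C(Nc1nc(-c2ccccn2)cs1)c1cccc([N+](=O)[O-])c1` has no number, its entry reading "not determined" (no result reported). Compound 4 `O=C(Nc1nc(-c2ccccn2)cs1)c1ccccc1Cl` is still unmeasured and changes compound 1 in one place: chloro in place of methyl on an aromatic carbon, with chloro in place of methyl on an aromatic carbon, ortho to a large group. Among the measured compounds shown here, no measured pair differs in one place, so no step guides this change, and the expectation starts from compound 1 at 6300 nM. In this assay, the expected step of a 1.3-fold lower number from compound 1 to compound 4 (0.10 log units; within the scatter) is small, slightly toward lower numbers and not beyond the scatter. The estimated value for compound 4 is 5000 nM, with an expected range of 2200 nM to 11000 nM.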

Compound 4, half-maximal effective concentration: 2000 nM
The estimate for compound 4 lay 2.5-fold (0.40 log units) above the measured number, and the stated range ends above it.
By their numbers in this assay, from the lowest: compounds 4 and 2 (each within the scatter of the next); then compound 1.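

In this assay, among these compounds, going from 2-methylphenyl to 2-chlorophenyl gives a 3.2-fold lower number from compound 1 to compound 4 (0.50 log units; beyond the scatter), the first step between compounds that differ in one place. Exchanging one heavy atom on this aromatic carbon is therefore enough to move the number beyond the scatter. No measurement available here accounts for the step. From the compounds shown here alone, whether other groups at this place would move the number as chloro does remains open, for example fluoro, an amine or a carboxylic acid. Going by these compounds, the effect of changes to the shared core also remains open.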